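A few compounds are considered here, and "the series" means these few. Any claim that something is new, unique, unknown or untested is made for them only; others in the source may bear on it.

Compound 1 `Cc1n[nH]c(-c2ccccc2NCC2=NCCN2)n1` is the reference point of the series: in an in vitro functional assay on cells (Fibroblast) for agonist activity at Alpha-1A adrenergic receptor (Homo sapiens) (a higher number here means that more compound is needed for the effect, a lower number that less compound is needed), compound 1 gives 794 nM. Among the measured compounds shown here, compound 2 `Cc1nc(-c2ccccc2NCC2=NCCN2)n(C)n1` differs only by a methyl in place of hydrogen on an aromatic nitrogen and in this assay compound 2 gives 1000 nM, a step of a 1.3-fold higher number from compound 1 to compound 2 (0.10 log units; within the scatter), so compound 1 and compound 2 sit within the scatter of each other and no measured step in the set exceeds the scatter.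

Compound 3 `c1ccc(-c2cn[nH]c2)c(NCC2=NCCN2)c1` follows from compound 1 by a different kind of change: 1H-pyrazol-4-yl in place of 3-methyl-1H-1,2,4-triazol-5-yl on an aromatic carbon. For the measured compounds named here, the only measured step, that from compound 1 to compound 2, alters a substituent within the same ring and does not touch the ring itself, so it bears only loosely on the present exchange. In this assay compound 3 is therefore expected near 1500 nM, with a range of 300 nM to 8000 nM. The step implied for this assay is estimated as a 1.9-fold higher number from compound 1 to compound 3 (0.28 log units; within the scatter), with no clear direction beyond the scatter.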

Compound 3, half-maximal effective concentration: 1.26 nM
Compound 3: the middle estimate sits 1200-fold (3.08 log units) above what was measured; measured number below the stated range.
By their numbers in this assay, from the lowest: compound 3; then compounds 1 and 2 (each within the scatter of the next).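

In this assay, among the compounds shown here, the aromatic carbon ortho to the group of 7 heavy atoms proves highly sensitive to the ring it carries, since 1H-pyrazol-4-yl in place of 3-methyl-1H-1,2,4-triazol-5-yl gives a 630-fold lower number from compound 1 to compound 3 (2.80 log units; beyond the scatter) and no earlier step came close to this size. The earlier change, a methyl on an aromatic nitrogen, stayed within the scatter, so this sensitivity appears only once the ring itself is exchanged. Nothing available explains the size of this step.

The exchange removes the methyl and alters the ring in one move, so the shown compounds cannot separate the two. A 1H-1,2,4-triazol-5-yl without the methyl, a 1-methyl-1H-pyrazol-4-yl or a plain phenyl at this carbon would divide the step between those parts.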